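Removing the aryl group from the lactam nitrogen

A few compounds are considered here, and "the series" means these few. Any claim that something is new, unique, unknown or untested is made for them only; others in the source may bear on it.

Measured compounds in a functional assay on HeLa cells (Homo sapiens) for antiproliferative activity, read by MTT assay, with a stated time of 72 h; on this read-out lower numbers stand for stronger inhibition and higher numbers for weaker inhibition:
compound 1, `COc1ccc(N2C(=O)COc3ccc(-c4cnc5ccccc5c4)cc32)cc1`, a limit of > 40000 nM.
compound 2, `COc1cccc(N2C(=O)COc3ccc(-c4cnc(Cl)c(NS(=O)(=O)c5ccc(F)cc5)c4)cc32)c1`, a limit of > 40000 nM.
compound 3, `O=C1COc2ccc(-c3cnc4ccccc4c3)cc2N1c1ccc(Cl)cc1`, a limit of > 40000 nM.

Every value shown in this assay is a limit rather than a number, and compound 2 sits at that limit with the limit of > 40000 nM in this assay, at which 3 of the 3 values shown sit. For the measured compounds named here, the one step between measured compounds, a step that the two limits leave unreadable from compound 1 to compound 3, is therefore unreadable in size. Compound 4, `O=C1COc2ccc(-c3cnc(Cl)c(NS(=O)(=O)c4ccc(F)cc4)c3)cc2N1`, is not yet measured. It differs from compound 2 by hydrogen in place of 3-methoxyphenyl on an amide-type nitrogen in a ring. No measured step changes the group on the amide-type nitrogen, so nothing among the shown compounds reads on this change, and the anchors themselves are limits only. The account therefore expects compound 4 to remain where compound 2 stands, most probably again at the limit, with an estimate of 60000 nM in the range 10000 nM to 300000 nM. The step this implies from compound 2 to compound 4, a step that the limit leaves unreadable from compound 2 to compound 4, is expected to be unreadable as well, with no direction beyond the scatter claimed.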

Compound 4, half-maximal inhibitory concentration: 15600 nM
For compound 4 the middle estimate is 3.8-fold (0.59 log units) above the measured one; measured number inside the range.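

In this assay, for the compounds shown here, hydrogen in place of 3-methoxyphenyl on the amide-type nitrogen in the ring gives an at least 2.5-fold lower number from compound 2 to compound 4 (0.40 log units; beyond the scatter), so this position, which no earlier readable step had touched, proves able to move the read-out. Going by these compounds alone, an aryl group on this nitrogen is thus not required for a measurable value, as compound 4 gives 15600 nM, the only value shown that is not a limit. The true size of the step stays unknown, and the other compounds offer no number to set it against: the limit of > 40000 nM in this assay, at which 3 of the 4 values shown sit.

On these data alone, whether the same change would bring compound 1 or compound 3 off the limit stays open, and the step between those two cannot be read. Also open, as far as these compounds go, is how a methyl group or a longer chain ending in an amine on this nitrogen would compare with hydrogen.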